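Series notes: aryl variation on the shared core

The compounds below may be only part of what the source reports. "The series", "measured", "known", "first", "only" and "open" are said of these compounds alone.

The shared core carries a four-carbon chain ending in a phenyl group and an aryl ring on the five-membered ring. Compound 1 `COc1ccc(-c2cn(C(=O)NCCCCc3ccccc3)c(=O)o2)cc1` gives 400 nM in an assay on isolated protein for inhibition of acid ceramidase (Homo sapiens), read by LC-MS, with a stated time of 1 h; on this read-out higher numbers stand for weaker inhibition and lower numbers for stronger inhibition. Compound 2 `COc1ccccc1-c1cn(C(=O)NCCCCc2ccccc2)c(=O)o1` gives 177 nM. Compound 3 `COc1cc(-c2cn(C(=O)NCCCCc3ccccc3)c(=O)o2)ccc1F` gives 80 nM and stands lowest of the three; its nearest neighbour is compound 2 a 2.2-fold lower number from compound 2 to compound 3 (0.34 log units; beyond the scatter), its furthest compound 1 a 5.0-fold lower number from compound 1 to compound 3 (0.70 log units; beyond the scatter). The remaining step, a 2.3-fold lower number from compound 1 to compound 2 (0.35 log units; beyond the scatter), is also modest.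

Compound 4 `O=C(NCCCCc1ccccc1)n1cc(-c2ccncc2)oc1=O` has not yet been measured. It differs from compound 3 in one place: pyridin-4-yl in place of 4-fluoro-3-methoxyphenyl on an aromatic carbon. None of the three measured steps replaces the carbon-only ring with a ring bearing a nitrogen; they only shift or add substituents on the same ring, each moving the number by a modest amount. The change to compound 4 removes both substituents of compound 3 and alters the ring itself, so the measured steps give direction only weakly. Compound 4 is therefore expected to give a higher number than compound 3, of a size comparable to the measured steps, and the expected value is 250 nM, with a range from 80 nM to 800 nM. This estimate corresponds to an expected step of a 3.1-fold higher number from compound 3 to compound 4 (0.49 log units; beyond the scatter).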

Compound 4, half-maximal inhibitory concentration: 18 nM
The estimate for compound 4 lay 14-fold (1.14 log units) above the measured number; the measured number lies below the stated range.
By their numbers in this assay, from the lowest: compound 4; then compound 3; then compound 2; then compound 1.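

Working notes on the aromatic carbon next to the ring oxygen: in this assay, a ring with a hetero atom at this position gives the lowest number of the series, and pyridin-4-yl in place of 4-fluoro-3-methoxyphenyl gives a 4.4-fold lower number from compound 3 to compound 4 (0.65 log units; beyond the scatter). The same kind of replacement gives a 9.8-fold lower number from compound 2 to compound 4 (0.99 log units; beyond the scatter) and a 22-fold lower number from compound 1 to compound 4 (1.35 log units; beyond the scatter), the last being the first large step in the series, so at this position, among these four compounds, neither a methoxy group nor a fluorine is required for the strongest inhibition, and the smaller pyridin-4-yl group outperforms all three substituted phenyl rings. No measurement here accounts for this gain.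

The change alters the ring and removes the substituents in a single step, so the shares of the ring nitrogen and of the lost groups remain unseparated; an unsubstituted phenyl ring at this position would bear directly on that. As far as these compounds go, whether the placement of the nitrogen matters also remains open, a question that pyridin-3-yl and pyridin-2-yl rings would address.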